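A few compounds are considered here, and "the series" means these few. Any claim that something is new, unique, unknown or untested is made for them only; others in the source may bear on it.

Compound 3 `CCCCc1ccc(Cn2ccc3cc(/C(C)=C/C(=O)Nc4ccccc4OCCCC(=O)O)ccc32)cc1` gives the lowest of the three numbers obtained in an assay on Prostate gland for inhibition of steroid 5-alpha-reductase (Rattus norvegicus); on this read-out higher numbers stand for weaker inhibition and lower numbers for stronger inhibition: in this assay compound 3 gives 100 nM. Its two neighbours stand close by. Compound 2 `CCCCCCCn1ccc2cc(/C(C)=C/C(=O)Nc3ccccc3OCCCC(=O)O)ccc21` gives 120 nM in this assay, and compound 1 `CCCn1ccc2cc(/C(C)=C/C(=O)Nc3ccccc3OCCCC(=O)O)ccc21` gives 190 nM. The steps among them are all small: a 1.6-fold lower number from compound 1 to compound 2 (0.20 log units; within the scatter), a 1.9-fold lower number from compound 1 to compound 3 (0.28 log units; within the scatter) and a 1.2-fold lower number from compound 2 to compound 3 (0.08 log units; within the scatter), each within the scatter, so no ordering among the three can be claimed.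

Compound 4 `CCCC(c1ccccc1)n1ccc2cc(/C(C)=C/C(=O)Nc3ccccc3OCCCC(=O)O)ccc21` has not yet been measured. It differs from compound 3 by 1-phenylbutyl in place of 4-butylbenzyl on an aromatic nitrogen. Among the measured compounds shown here, the steps that bear on this change are those that alter the group on the same aromatic nitrogen, namely the steps from compound 1 to compound 3 and from compound 2 to compound 3, and neither moved the number beyond the scatter. Compound 4 is therefore expected to give a number close to that of compound 3, with a 1.3-fold higher number from compound 3 to compound 4 (0.11 log units; within the scatter) as the estimated step. The estimate for compound 4 in this assay is 130 nM, with a range from 50 nM to 350 nM.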

Compound 4, half-maximal inhibitory concentration: 9.1 nM
Compound 4: the middle estimate sits 14-fold (1.15 log units) above what was measured; the whole stated range lies above it.
By their numbers in this assay, from the lowest: compound 4; then compounds 3, 2 and 1 (each within the scatter of the next).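

In this assay, among the compounds shown here, the group on the aromatic nitrogen proves able to move the number far more than the earlier compounds showed: propyl, heptyl and 4-butylbenzyl stayed within the scatter of one another, whereas 1-phenylbutyl brings an 11-fold lower number from compound 3 to compound 4 (1.04 log units; beyond the scatter), a 13-fold lower number from compound 2 to compound 4 (1.12 log units; beyond the scatter) and a 21-fold lower number from compound 1 to compound 4 (1.32 log units; beyond the scatter). This large step comes with little change in what is counted, since 4-butylbenzyl and 1-phenylbutyl each carry one six-membered aromatic ring of carbon only, no hydrogen-bond donors or acceptors and no net charge. Nothing available here accounts for the step.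

On these data alone, it remains open whether 1-phenylethyl, 1-phenylhexyl or plain benzyl on this nitrogen would give a similar number. Also open, as far as these compounds go, is how a chlorine or a methoxy group on the phenyl ring of 1-phenylbutyl would change it.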